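The compounds below may be only part of what the source reports. "The series", "measured", "known", "first", "only" and "open" are said of these compounds alone.

In a functional assay on 2008 cells (Homo sapiens) for inhibition (a lower number here means a stronger inhibitor of growth, a higher number a weaker inhibitor of growth), compound 1 `C=C/C=C\[C@H](C)[C@H](OC(N)=O)[C@@H](C)[C@H](O)CC/C=C\C(C)[C@@H](O)[C@@H](C)/C=C\CC[C@@H]1OC(=O)[C@H](C)[C@@H](OCOC)[C@@H]1C` gives 0.65 nM, compound 2 `C=C/C=C\[C@H](C)[C@H](OC(N)=O)[C@@H](C)[C@H](O)CC/C=C\C(C)[C@@H](O)[C@@H](C)/C=C\CC[C@@H]1O[C@@H](OC)[C@H](C)[C@@H](OCOC)[C@@H]1C` gives 4.7 nM and compound 3 `CCCCCC[C@H](OC(N)=O)[C@@H](C)[C@H](O)CC/C=C\C(C)[C@@H](O)[C@@H](C)/C=C\CC[C@@H]1O[C@@H](OC)[C@H](C)[C@@H](OCOC)[C@@H]1C` gives 29 nM, the highest number of the three. Compound 4 `CCCCCC(C)(C)[C@H](OC(N)=O)[C@@H](C)[C@H](O)CC/C=C\C(C)[C@@H](O)[C@@H](C)/C=C\CC[C@@H]1O[C@@H](OC)[C@H](C)[C@@H](OCOC)[C@@H]1C` differs from compound 3 at one place, on a saturated chain carbon bound to an oxygen next to a carbonyl group and a saturated chain carbon: a group of 8 heavy atoms (8 carbon; no ring) in place of a group of 6 heavy atoms (6 carbon; no ring), on a saturated chain carbon bound to an oxygen next to a carbonyl group and a saturated chain carbon. Within the data shown here, only one measured step touches this place, the modest 6.2-fold higher number from compound 2 to compound 3 (0.79 log units; beyond the scatter), where hexyl replaced 1-methylpenta-2,4-dien-1-yl. It gives no direction for the new group, so no change beyond the scatter is expected in this assay. The expected step is a 1.2-fold lower number from compound 3 to compound 4 (0.06 log units; within the scatter). For compound 4 the estimated value is 25 nM, with an expected range of 7 nM to 90 nM.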

Compound 4, concentration for 50% growth inhibition: 42 nM
For compound 4 the middle estimate is 1.7-fold (0.23 log units) below the measured one; measured number inside the range.
By their numbers in this assay, from the lowest: compound 1; then compound 2; then compounds 3 and 4 (each within the scatter of the next).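

In this assay the group of 8 heavy atoms on this saturated chain carbon cannot be told apart from hexyl (a 1.4-fold higher number from compound 3 to compound 4 (0.16 log units; within the scatter)). Set against the 1-methylpenta-2,4-dien-1-yl group, it gives a step beyond the scatter (an 8.9-fold higher number from compound 2 to compound 4 (0.95 log units; beyond the scatter)), so both saturated groups shown here stand above compound 2. No evidence given here accounts for either step.

The compounds shown leave open how an unsaturated chain without the diene, a phenyl ring or an amine would read at this place. They also leave open whether hexyl would give a similar step on the core of compound 1.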